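Swapping the aryl ring on a cytotoxic flavanone core

This account rests on a few compounds, and the source may have more. Where it says the series, first, only, none or still open, it means among the compounds named here.

Measured compounds:
- compound 1, `CC(C)=CCC/C(C)=C/Cc1c(O)cc2c(c1O)C(=O)C[C@@H](c1cc(O)cc(O)c1)O2`: 8500 nM
- compound 2, `COc1cc([C@@H]2CC(=O)c3c(cc(O)c(C/C=C(\C)C/C=C/C(C)(C)O)c3O)O2)ccc1O`: > 10000 nM

Going by the values given here, in a functional assay on THP-1 cells (Homo sapiens) for cytotoxicity, with a stated time of 72 h (on this read-out lower numbers stand for an effect already at smaller amounts and higher numbers for an effect only at larger amounts of compound), compound 1 gives 8500 nM, the only plain number among the two values shown. For compound 2 the read-out is a limit of the assay, > 10000 nM, not a measured number; this is the limit of > 10000 nM in this assay, at which 1 of the 2 values shown sits. Compound 1 thus stands as the single anchor on this read-out.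

Compound 3, `COc1cc([C@@H]2CC(=O)c3c(cc(O)c(C/C=C(\C)CCC=C(C)C)c3O)O2)cc(O)c1O`, has not yet been tested in this assay. It differs from compound 1 in one place: 3,4-dihydroxy-5-methoxyphenyl in place of 3,5-dihydroxyphenyl on a saturated ring carbon. Among the compounds with values here, no pair of measured compounds shows what such a change does, so the size of the step is open. The expectation is a step from compound 1 to compound 3 that stays near the scatter or drifts toward weaker effect, a 1.2-fold higher number from compound 1 to compound 3 (0.07 log units; within the scatter). Compound 3 is therefore estimated at 10000 nM, within a range from 4000 nM to 30000 nM, with a fair chance that only a limit is reported.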

Compound 3, half-maximal effective concentration: < 10000 nM
Compound 3 ended at the assay's limit; the forecaster's own chance of this, stated with the estimate: 45%; the middle value lies on the limit itself.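

No step from compound 1 to compound 3 can be read, because compound 3 carries only a limit of the assay: the limit of < 10000 nM in this assay, at which 1 of the 3 values shown sits.

The compounds shown leave open how far 3,4-dihydroxy-5-methoxyphenyl in place of 3,5-dihydroxyphenyl on the shared core moves the value in this assay.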